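What to expect from compound 3

The compounds below may be only part of what the source reports. "The series", "measured", "known", "first", "only" and "open" are said of these compounds alone.

Measured so far in an ADME assay on NHDF cells (Homo sapiens) for cytotoxicity; a lower number here means a stronger inhibitor, a higher number a weaker inhibitor
- compound 1 `COc1cc(/C=C2\CCC/C(=C\c3ccccc3Br)C2=O)cc(OC)c1OC` gives 12400 nM
- compound 2 `COc1cc(/C=C2\CCC/C(=C\c3cccc(O)c3)C2=O)cc(OC)c1OC` gives 25300 nM

Compound 2 (25300 nM) holds the higher of the two numbers. Compound 3 (`COc1cc(/C=C2\CCC/C(=C\c3ccc(O)c(Cl)c3)C2=O)cc(OC)c1OC`) differs from it in one place, on a double-bonded chain carbon bound to a double-bonded ring carbon (3-chloro-4-hydroxyphenyl in place of 3-hydroxyphenyl on a double-bonded chain carbon bound to a double-bonded ring carbon), where 3-chloro-4-hydroxyphenyl replaces 3-hydroxyphenyl. Within the data shown here, the only measured step at this place is modest (a 2.0-fold higher number from compound 1 to compound 2 (0.31 log units; beyond the scatter)), and there 3-hydroxyphenyl replaced 2-bromophenyl. Among the measured compounds shown here, that single step hints that a ring carrying a halogen may give the lower number, but no measured compound has the incoming group, so the evidence is thin. A modest move to a lower number in this assay is therefore expected (a 1.7-fold lower number from compound 2 to compound 3 (0.23 log units; within the scatter)). Compound 3 is expected at 15000 nM (estimated range 6000 nM to 32000 nM).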

Compound 3, half-maximal inhibitory concentration: 6900 nM
For compound 3 the middle estimate is 2.2-fold (0.34 log units) above the measured one, within the range that was stated.
By their numbers in this assay, from the lowest: compounds 3 and 1 (each within the scatter of the next); then compound 2.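

In this assay, this position now shows a clear drop: 3-chloro-4-hydroxyphenyl in place of 3-hydroxyphenyl gives a lower number (a 3.7-fold lower number from compound 2 to compound 3 (0.56 log units; beyond the scatter)). Measured against the 2-bromophenyl ring of compound 1, the same group gives a difference within the scatter (a 1.8-fold lower number from compound 1 to compound 3 (0.25 log units; within the scatter)), so these two halogen-bearing rings cannot be told apart here, while both read lower than the halogen-free ring of compound 2. Nothing available bears on why the number changes at this position.

The change adds a chlorine and also alters where the hydroxyl sits, and the compounds shown do not separate these two differences. Also open, from the compounds shown here alone, is how this assay would respond to a ring carrying an amine or a carboxylic acid at this place.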